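The compounds below may be only part of what the source reports. "The series", "measured", "known", "first", "only" and "open" are said of these compounds alone.

Notes on the series. Compound 1 `Cc1cnc(NC(=O)COc2ccc(/C=C3\SC(=O)NC3=O)cc2)s1` serves as the reference point. In a functional assay on MCF7 cells (Homo sapiens) for cytotoxicity, read by sulforhodamine B assay, with a stated time of 48 h (a higher number here means a weaker inhibitor of growth, a lower number a stronger inhibitor of growth), compound 1 gives only a limit, < 100000 nM. Compound 2 `CCCCC1=NC2(CCCC2)C(=O)N1C(=O)COc1ccc(/C=C2/SC(=O)NC2=O)cc1` likewise gives a limit in this assay, < 100000 nM. Compound 3 `O=C1NC(=O)/C(=C\c2ccc(OCC(=O)N3C(=O)c4ccccc4S3(=O)=O)cc2)S1` gives a limit as well in this assay, < 100000 nM. Within the data shown here, every value so far is therefore a limit, (the limit of < 100000 nM in this assay, at which 3 of the 3 values shown sit), and no step between measured compounds can be read from these numbers. Compound 4 `Cc1cc(NC(=O)COc2ccc(/C=C3\SC(=O)NC3=O)cc2)no1` differs from compound 1 by 5-methyl-1,2-oxazol-3-yl in place of 5-methyl-1,3-thiazol-2-yl on an amide-type nitrogen. Among the measured compounds shown here, with no measured step to lean on, the expected step is a step that the limit leaves unreadable from compound 1 to compound 4, nothing beyond the scatter. Compound 4 is estimated at 50000 nM, with a range from 10000 nM to 100000 nM, and quite possibly again only a limit.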

Compound 4, concentration for total growth inhibition: < 100000 nM
Compound 4: only a limit was reported; the forecaster's own chance of this, stated with the estimate: 70%; the middle value does not contradict the limit.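

Among these compounds, compound 1 and compound 4 both give only a limit in this assay, so no step between them can be read: the limit of < 100000 nM in this assay, at which 4 of the 4 values shown sit. The compounds shown leave open whether 5-methyl-1,2-oxazol-3-yl and 5-methyl-1,3-thiazol-2-yl differ at all in this read-out.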